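The compounds below may be only part of what the source reports. "The series", "measured", "known", "first", "only" and "open" are said of these compounds alone.

Series in a functional assay on B16-BL6 cells (Mus musculus) for cytotoxicity, read by MTT assay, with a stated time of 72 h; on this read-out lower numbers stand for stronger inhibition and higher numbers for weaker inhibition:

- compound 1 `COc1cc2cc(Cc3ccc(O)cc3)c(=O)oc2cc1O` gives > 100000 nM, a limit and not a number
- compound 2 `Oc1ccc(C[C@H]2COc3cc(O)ccc3C2)cc1` gives > 100000 nM, a limit and not a number
- compound 3 `COc1ccc(C(=O)CCc2c(OC)cc(O)cc2OC)cc1` gives 70100 nM

Compound 3 is the only one of the three with a measured number, so it cannot be ranked against another number in the series. Its two companions are reported only as limits. The position of the series is summed up by the limit of > 100000 nM in this assay, at which 2 of the 3 values shown sit. Activity in this assay is therefore faint across everything measured so far.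

The next compound is compound 4 `COc1cc(O)cc(OC)c1CCC(=O)c1ccc(O)cc1`, which has hydrogen in place of methyl on an oxygen on an aromatic ring, a methoxy to hydroxy change: hydrogen in place of methyl on an oxygen on an aromatic ring. Among the compounds with values here, no measured pair isolates this change, so no size can be taken from an earlier step. The expectation rests on compound 3 alone, at 70100 nM. No step beyond the scatter is expected in this assay, in either direction. A report of compound 4 only as a limit would not be surprising.

The expected change is a 1.1-fold higher number from compound 3 to compound 4 (0.06 log units; within the scatter). For compound 4 the estimated value is 80000 nM, with an expected range of 35000 nM to 160000 nM.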

Compound 4, half-maximal inhibitory concentration: 84400 nM
For compound 4 the middle estimate is 1.1-fold (0.02 log units) below the measured one; the range from low to high includes it.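

The series now holds its first pair that differs in one place: in this assay, the methoxy to hydroxy change, hydrogen in place of methyl on an oxygen on an aromatic ring, gives a 1.2-fold higher number from compound 3 to compound 4 (0.08 log units; within the scatter). Within the data shown here, at this position, then, this one exchange produces no step that can be told apart from repeat measurement, and this holds only for this pair at this faint level of activity. With the second measured number the pair gives a reading on this change, yet the series as a whole stays faint, and some of its values remain limits: the limit of > 100000 nM in this assay, at which 2 of the 4 values shown sit.

Steps involving compound 1 and compound 2 cannot be read, and the pair alone cannot say whether the same exchange would behave alike at either of the two methoxy groups that remain in compound 4. Also open, going by these compounds, is whether a larger replacement on that oxygen, such as a longer alkyl chain, or a group of another kind, such as an amine or a carboxylic acid, would move the number beyond the scatter.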